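Halogen swaps on the sulfonamide aryl group leave toxicity unread

A few compounds are considered here, and "the series" means these few. Any claim that something is new, unique, unknown or untested is made for them only; others in the source may bear on it.

Compounds measured in a functional assay on cells (leukaemia cell line, Homo sapiens) for inhibition, read by sulforhodamine B assay, with a stated time of 48 h (on this read-out lower numbers stand for higher toxicity in this test and higher numbers for lower toxicity in this test), each value being a limit of the assay and not a number:

- Compound 1 `O=S(=O)(Nc1ccc(F)c(Cl)c1)c1ccc(-c2cnc(C3CC3)o2)cc1` limit (> 100000 nM)
- Compound 2 `O=S(=O)(Nc1ccc(F)cc1F)c1ccc(-c2cnc(C3CC3)o2)cc1` limit (> 100000 nM)
- Compound 3 `O=S(=O)(Nc1cc(Cl)ccc1Cl)c1ccc(-c2cnc(C3CC3)o2)cc1` limit (> 100000 nM)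

Compound 3 therefore stands at a limit (> 100000 nM) and has no number of its own. The next compound is compound 4 `Cc1cc(Cl)cc(NS(=O)(=O)c2ccc(-c3cnc(C4CC4)o3)cc2)c1` which carries 3-chloro-5-methylphenyl in place of 2,5-dichlorophenyl on a sulfonamide nitrogen and keeps the rest of the structure.

Three measured steps change the group at this same place. They are a step that the two limits leave unreadable from compound 1 to compound 2 together with a step that the two limits leave unreadable from compound 1 to compound 3 and a step that the two limits leave unreadable from compound 2 to compound 3 (none of the three has a readable size). What they do show is shared by all the measured compounds (the limit of > 100000 nM in this assay, at which 3 of the 3 values shown sit).

From compound 3 (> 100000 nM) and these unreadable steps, no step beyond the usual scatter is expected in this assay in either direction. The step expected is a number no higher from compound 3 to compound 4 (the limit leaves the size open) (an estimate). The estimated value of compound 4 is 100000 nM with an expected range from 40000 nM to 150000 nM (most likely reported again as a limit).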

Compound 4, concentration lethal to 50% of the cells: 84900 nM
Estimate against measurement, compound 4: 1.2-fold (0.07 log units) above; the measured number falls inside the stated range.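

In this assay, going by these compounds alone, compound 4 gives 84900 nM, the only reading at this position that is a number and not a limit of the assay. The steps among compound 1, compound 2 and compound 3 cannot be read, and those three stay at a limit of the assay: the limit of > 100000 nM in this assay, at which 3 of the 4 values shown sit.

Against those limits, 3-chloro-5-methylphenyl on the sulfonamide nitrogen gives an at least 1.1-fold lower number from compound 3 to compound 4 (0.07 log units; that floor lies within the scatter), an at least 1.1-fold lower number from compound 2 to compound 4 (0.07 log units; that floor lies within the scatter) and an at least 1.1-fold lower number from compound 1 to compound 4 (0.07 log units; that floor lies within the scatter), so each step is known only as a floor and none is shown to go beyond the scatter.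

The compounds shown leave open how large the true gap is between compound 4 and the three compounds held at the limit, and whether any such gap belongs to the methyl group or to the single chlorine of the 3-chloro-5-methylphenyl group. They also leave open whether an amine or a carboxylic acid on this aromatic ring, in place of the halogens and the methyl group, would bring the number in this assay further down.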